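The compounds below may be only part of what the source reports. "The series", "measured", "known", "first", "only" and "open" are said of these compounds alone.

Compound 3 `CCOc1cccc(-c2ccc(CN(C(=O)C3CCCCC3)c3cccc(/C=C/C(=O)OC)c3)cc2)c1` gives 147 nM in an assay on isolated protein with Bile acid receptor (Homo sapiens) as the target; a higher number here means that more compound is needed for the effect, a lower number that less compound is needed; compound 1 `COC(=O)/C=C/c1cccc(N(Cc2ccc(/C=C/c3c(C)cc(C)cc3C)cc2)C(=O)C(C)C)c1` gives 149 nM; compound 2 `COC(=O)/C=C/c1cccc(N(Cc2ccc(/C=C/c3scnc3C)cc2)C(=O)C(C)C)c1` gives 228 nM.

Compound 3 has the lowest of the three numbers, yet its gap to compound 1 and to compound 2 lies within the usual scatter, so no order among the three can be read from these values. Compound 4 `CCOc1cccc(-c2ccc(CN(C(=O)C(C)C)c3cccc(/C=C/C(=O)OC)c3)cc2)c1` differs from compound 3 by isopropyl in place of cyclohexyl on a carbonyl carbon. Within the data shown here, the only measured step, a 1.5-fold higher number from compound 1 to compound 2 (0.18 log units; within the scatter), concerns a different place and stays within the scatter; no measured pair changes the group on the carbonyl carbon, so nothing here points to a shift in either direction. Compound 4 is therefore expected to give 150 nM, with a range from 60 nM to 400 nM. This estimate means a 1.0-fold higher number from compound 3 to compound 4 (0.01 log units; within the scatter), expected to stay within the scatter.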

Compound 4, half-maximal effective concentration: 173 nM
Estimate against measurement, compound 4: 1.2-fold (0.06 log units) below; the range from low to high includes it.
By their numbers in this assay, from the lowest: compounds 3, 1, 4 and 2 (each within the scatter of the next).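

In this assay the swap of cyclohexyl for isopropyl on the carbonyl carbon gives a 1.2-fold higher number from compound 3 to compound 4 (0.07 log units; within the scatter) and so no readable change, even though the ring is lost and the group shrinks to half its heavy atoms. As far as these values can tell, this position takes either group equally well. 3-Ethoxyphenyl in place of either ethenyl group on an aromatic carbon also shows no readable change, with a 1.3-fold lower number from compound 2 to compound 4 (0.12 log units; within the scatter) and with a 1.2-fold higher number from compound 1 to compound 4 (0.06 log units; within the scatter) as well.

From the compounds shown here alone, whether an amine or a longer chain on this carbonyl carbon would give a similar number remains open. Nothing measured here offers a reason for these results.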